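Bromo to fluoro on the benzoyl ring: cytotoxicity in cells

The compounds below may be only part of what the source reports. "The series", "measured", "known", "first", "only" and "open" are said of these compounds alone.

Compound 3 `COc1ccc2[nH]cc(CCCN3CCN(C(=O)CN4CCN(C(=O)c5cccc(Br)c5)CC4)CC3)c2c1` and compound 4 `COc1ccc2[nH]cc(CCCN3CCN(C(=O)CN4CCN(C(=O)c5cccc(F)c5)CC4)CC3)c2c1` differ by fluoro in place of bromo on an aromatic carbon. The same kind of change separates compound 1 `COc1ccc2[nH]cc(CCCN3CCN(C(=O)CN4CCN(C(=O)c5ccc(Br)cc5)CC4)CC3)c2c1` from compound 2 `COc1ccc2[nH]cc(CCCN3CCN(C(=O)CN4CCN(C(=O)c5ccc(F)cc5)CC4)CC3)c2c1`, where it reads (fluoro in place of bromo on an aromatic carbon); in that pair the halogen sits para to a large group, whereas in compound 4 it sits meta to a large group. The core of compound 1 and that of compound 3 differ by 3-bromophenyl in place of 4-bromophenyl on a carbonyl carbon. In an ADME assay on HEK293 cells (Homo sapiens) for cytotoxicity, read by MTT assay, with a stated time of 72 h (a higher number here means a weaker inhibitor, a lower number a stronger inhibitor), compound 1 gives 80500 nM. Compound 2 reaches only the limit of this assay, > 200000 nM, which is not a number. Compound 3 gives 57000 nM in this assay. The steps are an at least 2.4-fold higher number from compound 1 to compound 2 (0.39 log units; beyond the scatter), a 1.4-fold lower number from compound 1 to compound 3 (0.15 log units; within the scatter) and an at least 3.5-fold lower number from compound 2 to compound 3 (0.54 log units; beyond the scatter). Within the data shown here, the only measured bromo-to-fluoro step rests on (the limit of > 200000 nM in this assay, at which 1 of the 3 values shown sits), so its size is a floor. Compound 4 is therefore expected to show a 2.6-fold higher number from compound 3 to compound 4 (0.42 log units; beyond the scatter). Compound 4 is estimated at 150000 nM, between 60000 nM and 350000 nM.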

Compound 4, half-maximal inhibitory concentration: > 200000 nM
Compound 4 was reported as a limit; the forecaster's own chance of this, stated with the estimate: 40%; at least 1.3-fold (0.12 log units) between middle value and limit.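

In this assay fluoro in place of bromo gives an at least 3.5-fold higher number from compound 3 to compound 4 (0.54 log units; beyond the scatter) and the move from 4-bromophenyl to 3-fluorophenyl gives an at least 2.4-fold higher number from compound 1 to compound 4 (0.39 log units; beyond the scatter) as well. The number rises on both cores, so the direction of the bromo-to-fluoro change carries over, but each size is only a floor set by a limit of the assay: the limit of > 200000 nM in this assay, at which 2 of the 4 values shown sit. Nothing shows that the size carries over equally: the same change on two cores in this assay, an at least 2.4-fold higher number (0.39 log units; beyond the scatter) from compound 1 to compound 2 and an at least 3.5-fold higher number (0.54 log units; beyond the scatter) from compound 3 to compound 4; the limit leaves it open whether they differ.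

Going by these compounds, compound 2 and compound 4 both sit at limits, so the step between them cannot be read and the effect of where the fluoro sits stays open. Also open is how chloro or a methyl group would read on these cores, since only bromo and fluoro are shown.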